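A few compounds are considered here, and "the series" means these few. Any claim that something is new, unique, unknown or untested is made for them only; others in the source may bear on it.

Compound 3 `C=CC(=O)N1CC[C@H](N2C(=O)N(c3ccccc3)Cc3cnc(Nc4ccc(N5CCN(C)CC5)c(C)c4)nc32)C1` gives 51.7 mL/min/kg in an ADME assay on the whole organism (strain Sprague-Dawley) for pharmacokinetics, with Rattus norvegicus as the target, read by LC-MS, at a dose of 5 mg/kg by the intravenous route (on this read-out higher numbers stand for fast clearance and lower numbers for slow clearance), the lowest of the three numbers measured, though compound 2 `C=CC(=O)N1CC[C@H](N2C(=O)N(c3ccccc3)Cc3cnc(Nc4ccc(N5CCN(C)CC5)cc4OC)nc32)C1` at 86.7 mL/min/kg and compound 1 `C=CC(=O)N1CC[C@H](N2C(=O)N(c3ccccc3)Cc3cnc(Nc4ccc(N5CCN(C)CC5)cc4)nc32)C1` at 96.7 mL/min/kg both sit within the scatter of it. Compound 4 `C=CC(=O)N1CC[C@H](N2C(=O)N(c3ccccc3)Cc3cnc(Nc4ccc(N5CCN(C)CC5)c(OC)c4)nc32)C1` has not yet been measured; it differs from compound 3 by methoxy in place of methyl on an aromatic carbon. For the measured compounds named here, two measured steps bear on this change. The step of a 1.1-fold lower number from compound 1 to compound 2 (0.05 log units; within the scatter) placed a methoxy on the same ring, though at a different carbon, and the step of a 1.9-fold lower number from compound 1 to compound 3 (0.27 log units; within the scatter) put the methyl of compound 3 in place. Neither step left the scatter, and the two groups now being swapped gave numbers close to one another, so the exchange of methyl for methoxy is expected to move compound 4 little, if at all, beyond the scatter, with an expected step of a 1.3-fold higher number from compound 3 to compound 4 (0.10 log units; within the scatter). Compound 4 is therefore estimated at 65 mL/min/kg, with a range from 35 mL/min/kg to 120 mL/min/kg in this assay.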

Compound 4, clearance: 91.7 mL/min/kg
Estimate against measurement, compound 4: 1.4-fold (0.15 log units) below; low and high end bracket the measured number.
By their numbers in this assay, from the lowest: compounds 3, 2, 4 and 1 (each within the scatter of the next).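

Methoxy now stands on the carbon that carries the methyl of compound 3, ortho to a 4-methylpiperazin-1-yl group, and in this assay the exchange gives a 1.8-fold higher number from compound 3 to compound 4 (0.25 log units; within the scatter) with no separation of the two groups. Against hydrogen on that same carbon, the comparison gives a 1.1-fold lower number from compound 1 to compound 4 (0.02 log units; within the scatter), so hydrogen, methyl and methoxy at this position all remain within the scatter of one another. No measurement shown here offers an explanation for these numbers.

As far as these compounds go, whether a halogen such as fluorine, a nitrile or a primary amine on this carbon would give a step beyond the scatter stays open. Also open, from the compounds shown here alone, is whether a longer chain, such as ethoxy, would behave as methoxy does at this position.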